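Sulfonyl-to-carbamoyl swap on the aryl sulfonamide series

The source may report more compounds than this note shows. Statements on the series, on what has been measured and on what is new or still open speak of the compounds shown alone.

Two compounds of this series have numbers. Compound 1 `CCN(CC)S(=O)(=O)c1ccc(S(=O)(=O)N2CCC[C@@H](C(=O)NC3CN(C(=O)OC(C)(C)C)C3)C2)cc1` gives 100 nM in a functional assay on MIA PaCa-2 cells (Homo sapiens) for inhibition, read by MTT assay, with a stated time of 3 days; on this read-out lower numbers stand for stronger inhibition and higher numbers for weaker inhibition. Compound 2 `CC(C)c1noc(N2CCN(C(=O)[C@@H]3CCCN(S(=O)(=O)c4ccc(S(=O)(=O)C(C)C)cc4)C3)CC2)n1` gives 30 nM in this assay, the lowest of the two numbers, and the gap to compound 1 lies beyond the scatter. Compound 3 `CCN(CC)C(=O)c1ccc(S(=O)(=O)N2CCC[C@@H](C(=O)N3CCN(c4nc(C(C)C)no4)CC3)C2)cc1` is not yet measured; it differs from compound 2 by diethylcarbamoyl in place of isopropylsulfonyl on an aromatic carbon. Within the data shown here, no measured pair shows this change, so the expected step is a modest weakening: a 2.0-fold higher number from compound 2 to compound 3 (0.30 log units; within the scatter) is the estimate, with the number for compound 3 expected at 60 nM, plausibly between 20 nM and 200 nM.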

Compound 3, half-maximal inhibitory concentration: 70 nM
Beside the measured number, compound 3's estimate is 1.2-fold (0.07 log units) below it, within the range that was stated.
By their numbers in this assay, from the lowest: compound 2; then compounds 3 and 1 (each within the scatter of the next).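

Among these compounds, on an aromatic carbon para to a large group, diethylcarbamoyl in place of isopropylsulfonyl gives a 2.3-fold higher number from compound 2 to compound 3 (0.37 log units; beyond the scatter) in this assay, the first reading of a change at this position. The step is modest, and compound 3 still gives 70 nM, so the isopropylsulfonyl group is not required for activity in this series. Nothing available accounts for the size of the step.

The compounds shown leave open whether the carbonyl or the two ethyl chains carry the step. From the compounds shown here alone, how a primary carboxamide or a nitrile would read on this carbon is also open.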